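The source may hold more compounds than are shown below. What is called first, only, known or untested is meant among the compounds shown, and "the series" means these compounds.

Among the measured compounds shown here, compound 1 `COC[C@@H](C)[C@H](C)C(c1ccc(O)c(OC)c1)c1ccc(O)c(OC)c1` is the only member of this set with a number in a functional assay on HL-60 cells (Homo sapiens) for cytotoxicity, read by WST assay, with a stated time of 48 h; on this read-out higher numbers stand for weaker inhibition and lower numbers for stronger inhibition: compound 1 gives 73000 nM. Compound 2 `COc1cc(C(c2ccc(O)c(OC)c2)[C@H](CO)C(C)C)ccc1O` reaches only a limit of this assay, > 100000 nM. Compound 3 `COc1cc(C(c2ccc(O)c(OC)c2)[C@H](C)[C@@H](C)CO)ccc1O` likewise sits at a limit, > 100000 nM. Two of the three values therefore rest at the limit of > 100000 nM in this assay, at which 2 of the 3 values shown sit. The measured steps, an at least 1.3-fold higher number from compound 1 to compound 2 (0.13 log units; that floor lies within the scatter) and an at least 1.3-fold higher number from compound 1 to compound 3 (0.13 log units; that floor lies within the scatter), are floors rather than sizes, and a step that the two limits leave unreadable from compound 2 to compound 3 cannot be read at all. Compound 4 `CC[C@H](C(C)C)C(c1ccc(O)c(OC)c1)c1ccc(O)c(OC)c1` differs from compound 1 by 1-isopropylpropyl in place of 2-(methoxymethyl)-1-methylpropyl on a saturated chain carbon bound to two aromatic carbons. For the measured compounds named here, no measured step replaces 2-(methoxymethyl)-1-methylpropyl with 1-isopropylpropyl, so the steps toward compound 2 and compound 3 bear on it only loosely: both give floors whose size stays within the scatter. The step is therefore expected to be about a 1.2-fold higher number from compound 1 to compound 4 (0.07 log units; within the scatter), nothing beyond the scatter, with a real chance that only a limit is reported. Compound 4 is estimated at 85000 nM, with a range from 30000 nM to 250000 nM.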

Compound 4, half-maximal inhibitory concentration: 16000 nM
For compound 4 the middle estimate is 5.3-fold (0.73 log units) above the measured one; measured number below the stated range.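

In this assay, the group on the saturated chain carbon bound to two aromatic carbons now has a readable effect: 1-isopropylpropyl in place of 2-(methoxymethyl)-1-methylpropyl gives a 4.6-fold lower number from compound 1 to compound 4 (0.66 log units; beyond the scatter). The chain without oxygen also separates from both hydroxymethyl chains, with an at least 6.2-fold lower number from compound 3 to compound 4 (0.79 log units; beyond the scatter) and, for methyl in place of hydroxy, an at least 6.2-fold lower number from compound 2 to compound 4 (0.79 log units; beyond the scatter). These last two steps are floors and not sizes because compound 2 and compound 3 each start from a limit: the limit of > 100000 nM in this assay, at which 2 of the 4 values shown sit.

The compounds shown do not separate the loss of the methoxy oxygen from the change in branching between compound 1 and compound 4. On these data alone, how an amine, a carboxylic acid or a longer chain would read at this place also remains open.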